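The source may hold more compounds than are shown below. What is called first, only, known or untested is meant among the compounds shown, and "the series" means these compounds.

Measured compounds:
compound 1, `COc1ccc(C#N)cc1S(=O)(=O)Nc1cnc2ccccc2c1`, 38 nM
compound 2, `COc1ccc(Cl)cc1S(=O)(=O)Nc1cncc(-c2ccc(Cl)cc2)c1`, 198 nM
compound 3, `COC(=O)c1ccc(OC)c(S(=O)(=O)Nc2cccnc2)c1`, 1510 nM

Three compounds of the series have a number in an assay on isolated protein for inhibition of alkaline phosphatase, tissue-nonspecific isozyme (Homo sapiens); on this read-out higher numbers stand for weaker inhibition and lower numbers for stronger inhibition. Compound 1 gives 38 nM, compound 2 gives 198 nM and compound 3 gives 1510 nM. Compound 2 stands second highest of the three: its nearest neighbour is compound 1, whose number is lower by a margin beyond the scatter, and the furthest is compound 3, whose number is higher, also beyond the scatter. Going by the values given here, no two measured compounds differ in a single place, so no step within the measured set can be read off.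

Compound 4, `COc1ccc(Cl)cc1S(=O)(=O)Nc1cncc(-c2ccncc2)c1`, is not yet measured in this assay. It differs from compound 2 in one place: pyridin-4-yl in place of 4-chlorophenyl on an aromatic carbon. The change keeps the sulfonamide and the shared core of compound 2 and exchanges only the group on the aromatic carbon two atoms from the ring nitrogen, meta to a large group.

Among the compounds with values here, with no measured pair isolating this exchange, the expectation rests on compound 2 alone, 198 nM. A small shift toward a higher number is expected, close to the scatter, so the step from compound 2 to compound 4 is estimated as a 2.0-fold higher number from compound 2 to compound 4 (0.31 log units; beyond the scatter). Compound 4 is therefore expected to give about 400 nM, within roughly 120 nM to 1500 nM.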

Compound 4, half-maximal inhibitory concentration: 73 nM
Estimate against measurement, compound 4: 5.5-fold (0.74 log units) above, and the stated range ends above it.
By their numbers in this assay, from the lowest: compounds 1 and 4 (each within the scatter of the next); then compound 2; then compound 3.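

At the aromatic carbon two atoms from the ring nitrogen, meta to a large group, this assay now has its first comparison of compounds differing in one place: pyridin-4-yl in place of 4-chlorophenyl gives a 2.7-fold lower number from compound 2 to compound 4 (0.43 log units; beyond the scatter) and so a modest step beyond the scatter. This position therefore accepts a ring with one hetero atom and one hydrogen-bond acceptor in place of a carbon-only ring bearing chlorine, and the number falls on this exchange. Going by these compounds alone, no measurement at hand speaks to the reason for this step, and the single pair cannot separate the loss of the chlorine from the entry of the ring nitrogen.

Unsubstituted phenyl and pyridin-3-yl at the same carbon would divide the exchange into its two parts and show whether the place of the ring nitrogen matters. Going by these compounds, whether an aromatic ring is needed here at all remains open too, and a morpholine or a methyl group on this carbon would address that question.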